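Aryl Variation on the Carbonyl Carbon: Compound 2 to Compound 3

The source may hold more compounds than are shown below. What is called first, only, known or untested is meant among the compounds shown, and "the series" means these compounds.

Compound 1 `CN(C(=O)NC(=O)c1ccc(F)c(F)c1)c1nc(C(F)(F)F)c(C(=O)N/N=C/c2ccc(C(F)(F)F)cc2)s1`: 6.07 ug/mL
Compound 2 `CN(C(=O)NC(=O)c1ccc(Cl)cc1Cl)c1nc(C(F)(F)F)c(C(=O)N/N=C/c2ccc(C(F)(F)F)cc2)s1`: 9.4 ug/mL

Going by the values given here, in a functional assay on A549 cells (Homo sapiens) for inhibition, read by MTT assay, with a stated time of 72 h (on this read-out lower numbers stand for stronger inhibition and higher numbers for weaker inhibition), compound 2 gives 9.4 ug/mL, the higher of the two numbers measured so far, while compound 1 gives 6.07 ug/mL, which lies within the scatter of compound 2. Among the compounds with values here, the only measured step, a 1.5-fold higher number from compound 1 to compound 2 (0.19 log units; within the scatter), swapped one aryl group for another on the carbonyl carbon and moved the number by no more than the scatter.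

Compound 3 `CN(C(=O)NC(=O)c1cccc(C(F)(F)F)c1)c1nc(C(F)(F)F)c(C(=O)N/N=C/c2ccc(C(F)(F)F)cc2)s1` differs from compound 2 by 3-(trifluoromethyl)phenyl in place of 2,4-dichlorophenyl on a carbonyl carbon. Within the data shown here, this is the same kind of exchange, at the same place, as the one measured step, which itself stayed within the scatter. On that basis a change beyond the scatter is not expected; the step is estimated as a 1.2-fold lower number from compound 2 to compound 3 (0.07 log units; within the scatter). For compound 3 the expected value in this assay is 8 ug/mL, with a range from 4 ug/mL to 16 ug/mL.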

Compound 3, half-maximal inhibitory concentration: 6.2 ug/mL
Compound 3: middle estimate off by 1.3-fold (0.11 log units), on the high side; measured number inside the range.
By their numbers in this assay, from the lowest: compounds 1, 3 and 2 (each within the scatter of the next).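

At the carbonyl carbon, 3-(trifluoromethyl)phenyl now joins 3,4-difluorophenyl and 2,4-dichlorophenyl in this assay, and both new steps, a 1.5-fold lower number from compound 2 to compound 3 (0.18 log units; within the scatter) and a 1.0-fold higher number from compound 1 to compound 3 (0.01 log units; within the scatter), lie within the scatter. Going by these compounds alone, this exchange brings in more heavy atoms and fluorine in place of chlorine, yet no step among the three compounds goes beyond the scatter, so this position has so far tolerated all three aryl groups without a clear difference. Nothing available here gives a measured reason for this outcome.

The compounds shown leave open whether this position would keep its numbers with something other than a substituted phenyl ring on the carbonyl carbon, such as an amine, a carboxylic acid or a longer chain. They also leave open whether a change elsewhere on the shared core would move the number beyond the scatter.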